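Nitro for methoxy on the aryl ring of compound 1

The source may report more compounds than this note shows. Statements on the series, on what has been measured and on what is new or still open speak of the compounds shown alone.

Of the compounds shown here, three have been measured. Compound 1 `COc1ccc(-c2nnc3nnc(N4CCCCC4)n3n2)cc1` in a functional assay on HL-60 cells (Homo sapiens) for cytotoxicity, read by MTT assay, with a stated time of 72 h (on this read-out higher numbers stand for weaker inhibition and lower numbers for stronger inhibition), gives 12900 nM. Compound 2 `Fc1ccc(-c2nnc3nnc(N4CCCC4)n3n2)cc1` in this assay gives 4560 nM, and compound 3 `Fc1ccc(-c2nnc3nnc(N4CCCCC4)nn23)cc1` gives 30700 nM. Among the three numbers compound 1 stands second highest: compound 3 shows the nearest number, higher than that of compound 1 and beyond the usual scatter, while compound 2 shows the furthest, a lower number that also lies beyond the scatter. No pair of these compounds differs in a single place, so no single change has yet been tied to a step in this assay.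

Compound 4 `O=[N+]([O-])c1ccc(-c2nnc3nnc(N4CCCCC4)n3n2)cc1` is not yet measured. Relative to compound 1 the change is nitro in place of methoxy on an aromatic carbon. Within the data shown here, nothing among the measured compounds shows this exchange, so the direction is open. All three measured values sit in a narrow band, and no step beyond the scatter is expected from compound 1 to compound 4; the expected step is a 1.3-fold lower number from compound 1 to compound 4 (0.11 log units; within the scatter). Compound 4 is estimated at 10000 nM in this assay, with a range from 3500 nM to 30000 nM.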

Compound 4, half-maximal inhibitory concentration: 610 nM
The estimate for compound 4 lay 16-fold (1.21 log units) above the measured number; measured number outside the range, below it.
By their numbers in this assay, from the lowest: compound 4; then compound 2; then compound 1; then compound 3.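

In this assay, nitro in place of methoxy on an aromatic carbon, para to a large group, comes with a 21-fold lower number from compound 1 to compound 4 (1.33 log units; beyond the scatter). Among these compounds, this is the first single-place step, and it shows that this aryl position alone, with the rest of compound 1 held fixed, can move the read-out far beyond the scatter. The earlier compounds, none linked to another by a single change, could not tie any step to this position, and no measurement at hand accounts for this one.

One pair leaves open whether the step reflects the arrival of nitro, the departure of methoxy or both, and a plain hydrogen, a nitrile, a trifluoromethyl or an amine on the same carbon would help separate these readings. Also open, as far as these compounds go, is whether the same exchange gives a step of similar size when the rest of the molecule is that of compound 2 or compound 3, which differ from compound 1 in more than one place.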